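Swapping a Benzyl Substituent: Methyl to Trifluoromethyl

A few compounds are considered here, and "the series" means these few. Any claim that something is new, unique, unknown or untested is made for them only; others in the source may bear on it.

Compound 1, `Cc1cc(Nc2nc(NCc3ccc(F)cc3)nc3ccccc23)n[nH]1`: 20 nM
Compound 2, `Cc1cc(Nc2nc(NCc3ccc(Cl)cc3)nc3ccccc23)n[nH]1`: 380 nM
Compound 3, `Cc1ccc(CNc2nc(Nc3cc(C)[nH]n3)c3ccccc3n2)cc1`: 110 nM

Within the data shown here, these three compounds share one core and differ only in the single group on the benzyl ring. In an assay for inhibition of high affinity nerve growth factor receptor (Homo sapiens), read by HTRF, with a stated time of 30 min, in the presence of a further agent that is not named here (a higher number here means a weaker inhibitor, a lower number a stronger inhibitor), compound 1 gives 20 nM, compound 2 gives 380 nM and compound 3 gives 110 nM. Compound 3 therefore stands second highest of the three, with compound 2 nearest and compound 1 furthest. Compound 4, `Cc1cc(Nc2nc(NCc3ccc(C(F)(F)F)cc3)nc3ccccc23)n[nH]1`, has not yet been measured; it differs from compound 3 by trifluoromethyl in place of methyl on an aromatic carbon. Three steps at this same carbon bear on the question: a 19-fold higher number from compound 1 to compound 2 (1.28 log units; beyond the scatter), a 5.5-fold higher number from compound 1 to compound 3 (0.74 log units; beyond the scatter) and a 3.5-fold lower number from compound 2 to compound 3 (0.54 log units; beyond the scatter). The two halogens differ widely and methyl sits between them, so in this assay a modest rise is expected for compound 4: a 2.7-fold higher number from compound 3 to compound 4 (0.44 log units; beyond the scatter). Compound 4 is thus estimated at 300 nM, within 80 nM to 1200 nM.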

Compound 4, half-maximal inhibitory concentration: 1400 nM
The estimate for compound 4 lay 4.7-fold (0.67 log units) below the measured number; the measured number lies above the stated range.
By their numbers in this assay, from the lowest: compound 1; then compound 3; then compound 2; then compound 4.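

In this assay, trifluoromethyl proves the weakest of the four groups at this carbon, extending the range past chloro: (a 13-fold higher number from compound 3 to compound 4 (1.10 log units; beyond the scatter)), (a 3.7-fold higher number from compound 2 to compound 4 (0.57 log units; beyond the scatter)) and (a 70-fold higher number from compound 1 to compound 4 (1.85 log units; beyond the scatter)). The order from the lowest number is now fluoro, methyl, chloro, trifluoromethyl, so compound 1 stays the strongest inhibitor and compound 4 marks the new upper end. Nothing available here accounts for this order.

Still open, as far as these compounds go, is where a methoxy group, an amine or a carboxylic acid on this carbon would fall, and whether any group gives a lower number than fluoro.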